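The source may hold more compounds than are shown below. What is called first, only, known or untested is meant among the compounds shown, and "the series" means these compounds.

Working notes on the series. In an assay for inhibition of Indoleamine 2,3-dioxygenase 1 (Homo sapiens), read by fluorescence, with a stated time of 24 h (a higher number here means a weaker inhibitor, a lower number a stronger inhibitor), compound 2 `NS(=O)(=O)CC(=O)NCCSc1nonc1/C(=N/O)Nc1ccc(F)c(C(F)F)c1` gives 13 nM and stands level with compound 3 `O=C(NCCSc1nonc1/C(=N/O)Nc1ccc(F)c(C(F)F)c1)C1CS(=O)(=O)C1`, which gives 13 nM; together they are the lowest of the three numbers, with compound 1 `NS(=O)(=O)CC(=O)NCCSc1nonc1/C(=N/O)Nc1cccc(C(F)F)c1`, at 17 nM, the furthest off, all three within the scatter of one another. The two measured steps were a 1.3-fold lower number from compound 1 to compound 2 (0.12 log units; within the scatter) and no change at the digits printed from compound 2 to compound 3 (within the scatter).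

Compound 4 `N#Cc1cccc(N/C(=N\O)c2nonc2SCCNC(=O)CS(N)(=O)=O)c1` differs from compound 2 by 3-cyanophenyl in place of 3-(difluoromethyl)-4-fluorophenyl on an amine nitrogen. Among the compounds with values here, the fluoro added in the step from compound 1 to compound 2 is removed again here, and that step lay within the scatter; the change from difluoromethyl to nitrile on the same ring has no measured counterpart, and the step from compound 2 to compound 3 sits at the other end of the shared core and does not bear on it. Given that compound 2 gives 13 nM, the expected step is a 1.9-fold higher number from compound 2 to compound 4 (0.28 log units; within the scatter), most likely within the scatter with a slight lean toward a higher number. Compound 4 is therefore estimated at 25 nM in this assay, with a range of 10 nM to 70 nM.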

Compound 4, half-maximal inhibitory concentration: 44 nM
Beside the measured number, compound 4's estimate is 1.8-fold (0.25 log units) below it; the measured number falls inside the stated range.
By their numbers in this assay, from the lowest: compounds 2, 3 and 1 (each within the scatter of the next); then compound 4.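

Unlike the two earlier steps, the change of aryl group on the amine nitrogen moves the number in this assay beyond the scatter, giving a 3.4-fold higher number from compound 2 to compound 4 (0.53 log units; beyond the scatter). The single replacement of difluoromethyl by cyano on an aromatic carbon also lies beyond the scatter, at a 2.6-fold higher number from compound 1 to compound 4 (0.41 log units; beyond the scatter), whereas the fluoro change alone stayed within it, at a 1.3-fold lower number from compound 1 to compound 2 (0.12 log units; within the scatter), so the step from compound 2 to compound 4 does not depend on removing the fluoro. Nothing among the data offers an explanation for the step to compound 4.

Still open, on these data alone, is how a trifluoromethyl, a chloro or an amine would compare on the same ring in place of the nitrile. Also open, as far as these compounds go, is whether the nitrile gives a similar step when paired with the four-membered ring amide of compound 3.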